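The compounds below may be only part of what the source reports. "The series", "measured", "known", "first", "only" and "open" are said of these compounds alone.

Working notes on the series. In an assay on isolated protein for binding affinity to melanin-concentrating hormone receptor 1 (Homo sapiens) (a higher number here means a weaker inhibitor, a lower number a stronger inhibitor), compound 1 `CN(C(=O)N1CC[C@H](n2cnc3cc(-c4ccc(Cl)cc4)sc3c2=O)C1)[C@H]1CCN(CC2CC2)C1` gives 3 nM, compound 2 `Cc1ccc(-c2cc3ncn([C@H]4CCN(C(=O)N(C)[C@H]5CCN(C)C5)C4)c(=O)c3s2)c(C)c1` gives 49 nM, and compound 3 `Cc1ccc(-c2cc3ncn([C@H]4CCN(C(=O)N(C)[C@H]5CCN(C6CCOCC6)C5)C4)c(=O)c3s2)c(C)c1` gives 70 nM, so compound 3 carries the highest of the three numbers, with compound 2 within the scatter and compound 1 far below. Compound 4 `CCOc1ccc(-c2cc3ncn([C@H]4CCN(C(=O)N(C)[C@H]5CCN(C6CCOCC6)C5)C4)c(=O)c3s2)c(Cl)c1` differs from compound 3 by 2-chloro-4-ethoxyphenyl in place of 2,4-dimethylphenyl on an aromatic carbon. For the measured compounds named here, the only measured step, a 1.4-fold higher number from compound 2 to compound 3 (0.15 log units; within the scatter), concerns the amine nitrogen and does not bear on this change; compound 1 also carries a chlorine on its aryl ring, but it differs from compound 3 in more than one place, so no single step covers the aryl exchange. The step of a 1.8-fold lower number from compound 3 to compound 4 (0.24 log units; within the scatter) is therefore expected to be moderate, toward a lower number, with wide uncertainty. For compound 4 the estimate is 40 nM, within 12 nM to 130 nM.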

Compound 4, inhibition constant: 14 nM
The estimate for compound 4 lay 2.9-fold (0.46 log units) above the measured number; measured number inside the range.
By their numbers in this assay, from the lowest: compound 1; then compound 4; then compounds 2 and 3 (each within the scatter of the next).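

At the aromatic carbon next to the ring sulfur, 2-chloro-4-ethoxyphenyl in place of 2,4-dimethylphenyl gives a 5.0-fold lower number from compound 3 to compound 4 (0.70 log units; beyond the scatter) in this assay. For the compounds shown here, this position therefore responds more clearly than the amine nitrogen, where the only comparison is a 1.4-fold higher number from compound 2 to compound 3 (0.15 log units; within the scatter). No available measurement explains the change.

Going by these compounds alone, the single exchange alters both aryl substituents, so the chlorine and the ethoxy contributions remain inseparable. Also open, on these data alone, is how a 2-chlorophenyl or a 2-chloro-4-methoxyphenyl group would compare at this position.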